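The source may hold more compounds than are shown below. What is called first, only, known or untested is meant among the compounds shown, and "the series" means these compounds.

Of the compounds shown here, two have been measured so far in a functional assay on MDA-MB-231 cells (Homo sapiens) for inhibition, read by MTT assay, with a stated time of 72 h; on this read-out higher numbers stand for weaker inhibition and lower numbers for stronger inhibition. Compound 1 `C=CC(=O)Nc1cccc(NC(=O)CSc2nc(Nc3ccc(F)cc3)c3ccccc3n2)c1` gives 9490 nM, and compound 2 `C=CC(=O)Nc1cccc(NC(=O)CSc2nc(Nc3ccc(Br)cc3)c3ccccc3n2)c1` gives 17300 nM; compound 2 carries the larger of the two numbers, but the step of a 1.8-fold higher number from compound 1 to compound 2 (0.26 log units; within the scatter) lies within the usual scatter, so the two cannot be told apart. Compound 3 `C=CC(=O)Nc1cccc(NC(=O)CSc2nc(Nc3cc(OC)c(OC)c(OC)c3)c3ccccc3n2)c1` differs from compound 2 in one place: 3,4,5-trimethoxyphenyl in place of 4-bromophenyl on a nitrogen on an aromatic ring. Within the data shown here, the only measured step concerns an exchange of one halogen for another and has no bearing on a trimethoxyphenyl group; nothing measured here touches a change of this kind. Among the measured compounds shown here, with no relevant precedent, no step beyond the scatter in this assay can be expected in either direction, and the range must stay wide. Compound 3 is therefore estimated at 12000 nM, between 3000 nM and 45000 nM. The expected step from the measured number, a 1.4-fold lower number from compound 2 to compound 3 (0.16 log units; within the scatter), is one that the scatter alone could produce.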

Compound 3, half-maximal inhibitory concentration: > 50000 nM
Compound 3 was reported as a limit; the forecaster's own chance of this, stated with the estimate: 15%; at least 4.1-fold (0.61 log units) between middle value and limit.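

In this assay, the group on this nitrogen turns out to matter: the exchange of one halogen for another could not be told apart from the scatter, whereas the 3,4,5-trimethoxyphenyl group produces a clear change towards weaker inhibition, with an at least 2.8-fold higher number from compound 2 to compound 3 (0.46 log units; beyond the scatter) and an at least 5.2-fold higher number from compound 1 to compound 3 (0.72 log units; beyond the scatter). As far as these compounds go, compound 3 is reported only as a limit of the assay, so both steps are minimum sizes and the true gap remains unknown: the limit of > 50000 nM in this assay, at which 1 of the 3 values shown sits.

From the compounds shown here alone, it remains open which part of the 3,4,5-trimethoxyphenyl group counts, and a phenyl ring carrying a single methoxy group would begin to separate one such group from the full set. Also open, going by these compounds, is how this position responds to a different kind of group, such as a longer alkyl chain or a phenyl ring bearing an amine or a carboxylic acid, and whether any such group gives stronger inhibition than compound 1 and compound 2.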